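The source may report more compounds than this note shows. Statements on the series, on what has been measured and on what is new or still open speak of the compounds shown alone.

Working notes on the series. The shared core appears first in compound 1 `COc1ccc(-c2nc(SCC(=O)c3sc(-c4ccccc4)nc3C)[nH]c(=O)c2C#N)cc1` and compound 2 `COc1ccc(-c2nc(C)c(C(=O)CSc3nc(-c4ccc(Cl)cc4)c(C#N)c(=O)[nH]3)s2)cc1`. In an ADME assay on HEK293 cells (Homo sapiens) for cytotoxicity, read by MTT assay, with a stated time of 48 h (a lower number here means a stronger inhibitor, a higher number a weaker inhibitor), compound 1 gives 76200 nM. In this assay compound 2 gives 63000 nM. Both of these values lie within the scatter of each other, so no order between compound 1 and compound 2 can be read from them.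

Compound 3 `COc1ccc(-c2nc(C)c(C(=O)CSc3nc(-c4ccc(OC)cc4)c(C#N)c(=O)[nH]3)s2)cc1` carries a 4-methoxyphenyl group on the core. In this assay compound 3 gives "not determined" (no result reported); compound 3 therefore has no single number here, so compound 3 cannot be placed relative to compound 1 or compound 2 on the numbers available.

Compound 4 `COc1ccc(-c2nc(C)c(C(=O)CSc3nc(-c4cccc(OC)c4)c(C#N)c(=O)[nH]3)s2)cc1` is the next point in the series. The change from compound 3 to compound 4 is 3-methoxyphenyl in place of 4-methoxyphenyl on an aromatic carbon. Within the data shown here, no step between measured compounds isolates this change. Given that compound 1 and compound 2 sit close together in this assay, the step from compound 3 to compound 4 in this assay is expected to be none beyond the scatter, in no preferred direction. Compound 4 is expected to give about 70000 nM in this assay, with a range from 30000 nM to 160000 nM.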

Compound 4, half-maximal inhibitory concentration: 95400 nM
The estimate for compound 4 lay 1.4-fold (0.13 log units) below the measured number; low and high end bracket the measured number.
By their numbers in this assay, from the lowest: compounds 2, 1 and 4 (each within the scatter of the next).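

This position now has its first readable step: in this assay, 3-methoxyphenyl in place of 4-chlorophenyl on the aromatic carbon opposite the ring nitrogen gives a 1.5-fold higher number from compound 2 to compound 4 (0.18 log units; within the scatter), so this exchange of aryl groups shows no difference that can be told from the scatter. The change from 4-methoxyphenyl to 3-methoxyphenyl itself cannot be read, since compound 3 has no single number. No measurement on hand offers an explanation for these values.

From the compounds shown here alone, what a group of another kind at this position would do stays open, for example an amine or a carboxylic acid in place of the aryl group. The compounds shown also leave open whether any change at this position can move the number beyond the scatter.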